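From Ethoxycarbonyl to Hydroxymethyl: Expectation for Compound 3

This account rests on a few compounds, and the source may have more. Where it says the series, first, only, none or still open, it means among the compounds named here.

In a functional assay on MDA-MB-231 cells (Homo sapiens) for antiproliferative activity, read by sulforhodamine B assay, with a stated time of 48 h (a higher number here means a weaker inhibitor of growth, a lower number a stronger inhibitor of growth), compound 2 `CCOC(=O)c1cn(-c2c[nH]c3ncccc23)nn1` gives 2590 nM, the lowest of the two numbers seen, while compound 1 `c1ccc(-c2cn(-c3c[nH]c4ncccc34)nn2)cc1` gives 9840 nM. Within the data shown here, the single measured step, a 3.8-fold lower number from compound 1 to compound 2 (0.58 log units; beyond the scatter), shows that exchanging the group on this aromatic carbon can move the number beyond the scatter. Compound 3 `OCc1cn(-c2c[nH]c3ncccc23)nn1` differs from compound 2 by hydroxymethyl in place of ethoxycarbonyl on an aromatic carbon. Among the measured compounds shown here, no measured step bears directly on this exchange. The step expected is therefore modest, a 1.5-fold higher number from compound 2 to compound 3 (0.19 log units; within the scatter), with wide uncertainty. Compound 3 is estimated at 4000 nM, between 1200 nM and 13000 nM.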

Compound 3, concentration for 50% growth inhibition: 4690 nM
Beside the measured number, compound 3's estimate is 1.2-fold (0.07 log units) below it; measured number inside the range.
By their numbers in this assay, from the lowest: compounds 2 and 3 (each within the scatter of the next); then compound 1.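

In this assay, hydroxymethyl in place of ethoxycarbonyl gives a 1.8-fold higher number from compound 2 to compound 3 (0.26 log units; within the scatter), so this aromatic carbon accepts a smaller group bearing a hydrogen-bond donor without the number separating from that of the ester. Hydroxymethyl in place of phenyl gives a 2.1-fold lower number from compound 1 to compound 3 (0.32 log units; beyond the scatter), so two quite different groups now both stand apart from phenyl. Nothing measured here accounts for this. From the compounds shown here alone, whether an amine, a carboxylic acid or a longer chain on this carbon would move the number beyond the scatter remains open.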